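Antiproliferative series: trifluoromethoxy in place of trifluoromethyl

The compounds below may be only part of what the source reports. "The series", "measured", "known", "first", "only" and "open" are said of these compounds alone.

Measured so far in a functional assay on SKHep cells (Homo sapiens) for antiproliferative activity, read by MTT assay, with a stated time of 12 h; on this read-out higher numbers stand for weaker inhibition and lower numbers for stronger inhibition:
Compound 1 `COc1ccc2c(=O)cc(/C=C/c3ccc(OC(F)(F)F)cc3)oc2c1` gives > 40000 nM, a limit of the assay and not a number.
Compound 2 `COc1cc(/C=C/c2cc(=O)c3c(OC)cc(OC)cc3o2)cc(OC)c1` gives 23700 nM.
Compound 3 `COc1cc(OC)c2c(=O)cc(/C=C/c3ccc(C(F)(F)F)cc3)oc2c1` gives 20600 nM.

Compound 3 holds the lowest of the two numbers shown, with compound 2 nearest; that gap lies within the usual scatter, so no order between compound 3 and compound 2 is claimed. Compound 1 stands apart at the limit (the limit of > 40000 nM in this assay, at which 1 of the 3 values shown sits); it carries trifluoromethoxy on a core of its own and is not a one-place neighbour of any measured compound.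

Compound 4 `COc1cc(OC)c2c(=O)cc(/C=C/c3ccc(OC(F)(F)F)cc3)oc2c1` is still to be measured. It differs from compound 3 by trifluoromethoxy in place of trifluoromethyl on an aromatic carbon. Going by the values given here, no pair of measured compounds differs in exactly one place, so no measured step fixes the size of this change. Among the compounds with values here, compound 1 is the only measured compound bearing trifluoromethoxy and yields only a limit. A small step in this assay toward a higher number is expected from compound 3 to compound 4, a 1.4-fold higher number from compound 3 to compound 4 (0.13 log units; within the scatter), not clearly beyond the scatter. Compound 4 is expected to give 28000 nM in this assay, within 12000 nM to 60000 nM.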

Compound 4, half-maximal inhibitory concentration: 12500 nM
Beside the measured number, compound 4's estimate is 2.2-fold (0.35 log units) above it; measured number inside the range.
By their numbers in this assay, from the lowest: compounds 4, 3 and 2 (each within the scatter of the next). At a limit, above all of these: compound 1.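

In this assay, the exchange of trifluoromethyl for trifluoromethoxy, on an aromatic carbon para to a large group, now has a measured size on the shared core (a 1.6-fold lower number from compound 3 to compound 4 (0.22 log units; within the scatter)), so the two groups are not told apart at this position. Going by these compounds alone, with trifluoromethoxy held fixed, methoxy in place of hydrogen on an aromatic carbon gives the first step beyond the scatter (an at least 3.2-fold lower number from compound 1 to compound 4 (0.50 log units; beyond the scatter)). Compound 1 stands at a limit and not a number, so that step has a lower bound and no exact size: (the limit of > 40000 nM in this assay, at which 1 of the 4 values shown sits).

As far as these compounds go, whether this position responds to any group further from these two, such as an amine or a carboxylic acid, remains open. A single exchange on one core also leaves open whether the same result would hold on the core of compound 1.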